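The source may report more compounds than this note shows. Statements on the series, on what has been measured and on what is new or still open speak of the compounds shown alone.

Measured compounds in an ADME assay on Huh-7 cells (Homo sapiens) for cytotoxicity, read by MTT assay, with a stated time of 48 h; a higher number here means that more compound is tolerated, a lower number that less compound is tolerated:
compound 1 `CN(C)CCCCC(=O)Nc1ccc(CN2N=C(c3ccc(F)cc3)C3C=CC=CC3C2=O)cc1` gives 77700 nM
compound 2 `CN(C)CCCCNC(=O)Nc1ccc(CN2N=C(c3ccc(F)cc3)C3C=CC=CC3C2=O)cc1` gives 46600 nM
compound 3 `CN(C)CCCCOC(=O)Nc1ccc(Cn2nc(-c3cncnc3)c3ccccc3c2=O)cc1` gives 65300 nM

In this assay compound 3 sits between compound 1 and compound 2; its gap to compound 1 and its gap to compound 2 both lie within the scatter, so the three numbers read as a single level. Among the measured compounds shown here, the only step among the measured compounds, a 1.7-fold lower number from compound 1 to compound 2 (0.22 log units; within the scatter), alters the chain on the carbonyl carbon and leaves the shared core untouched; it too stays within the scatter.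

Compound 4 `CN(C)CCCCOC(=O)Nc1ccc(Cn2nc(-c3ccc(C(F)(F)F)cc3)c3ccccc3c2=O)cc1` has not yet been measured. It differs from compound 3 by 4-(trifluoromethyl)phenyl in place of pyrimidin-5-yl on an aromatic carbon. For the measured compounds named here, no measured pair varies the group at this place of the core, so the step from compound 1 to compound 2 bears on the question only loosely, as a sign that changes have so far not moved this assay beyond the scatter. The change from compound 3 to compound 4 is of another kind, and nothing in the data fixes its direction. The expectation is therefore a step of a 1.2-fold lower number from compound 3 to compound 4 (0.07 log units; within the scatter), within the scatter. For compound 4 the estimated value in this assay is 55000 nM, with a range from 25000 nM to 120000 nM.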

Compound 4, half-maximal cytotoxic concentration: 3360 nM
Compound 4: middle estimate off by 16-fold (1.21 log units), on the high side, and the stated range ends above it.
By their numbers in this assay, from the lowest: compound 4; then compounds 2, 3 and 1 (each within the scatter of the next).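

In this assay, 4-(trifluoromethyl)phenyl in place of pyrimidin-5-yl on the aromatic carbon next to the ring nitrogen gives a 19-fold lower number from compound 3 to compound 4 (1.29 log units; beyond the scatter). This makes the position the only place among the compounds shown where a single change moves the number beyond the scatter, whereas the one earlier step, a 1.7-fold lower number from compound 1 to compound 2 (0.22 log units; within the scatter), alters the chain on the carbonyl carbon and stays within it. No measurement among the data speaks to why less compound is tolerated with this group at this place.

The step exchanges a ring with hetero atoms for a carbon-only ring and adds trifluoromethyl at once, so the compounds shown cannot separate the loss of the ring nitrogens from the arrival of the trifluoromethyl group; plain phenyl or pyridin-3-yl at the same place would divide the two contributions. Also open, from the compounds shown here alone, is whether the same exchange has a comparable size when the chain is attached through the amide of compound 1 or the urea of compound 2 rather than the carbamate of compound 3 and compound 4.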